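The compounds below may be only part of what the source reports. "The series", "measured", "known", "first", "only" and "open" are said of these compounds alone.

Measured so far:
compound 1 `OC[C@H]1O[C@@H](n2cnc3c(NCc4ccccc4)nccc32)C[C@@H]1O`: 8%.
compound 2 `OCCNc1[nH]ccc2ncnc1-2`: only a limit, < 5%.

Going by the values given here, in a functional assay on EL4 cells (Mus musculus) for inhibition, tested at 100 uM (a lower number here means less inhibition, a higher number more inhibition at the concentration tested (going by the name of the read-out)), compound 1 gives 8%, the single number in the set. For compound 2 the result is a limit of the assay and not a number, < 5%. Among the compounds with values here, compound 1 therefore stands close to the limit of < 5% in this assay, at which 1 of the 2 values shown sits, with no room for a fall beyond the scatter and no measured step to lean on.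

Compound 3 `OC[C@H]1O[C@@H](n2cnc3cnccc32)C[C@@H]1O` is the next candidate. It differs from compound 1 in one place: hydrogen in place of benzylamino on an aromatic carbon. Within the data shown here, no measured pair shows what a change of this kind does here, so no direction can be read from the data. The step of a number 3 percentage points lower from compound 1 to compound 3 (within the scatter) is expected to stay within the scatter, because compound 1 already gives 8%. Compound 3 is therefore estimated at 5%, in the range 0% to 15%, with a real chance that only a limit is reported.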

Compound 3, a percentage reported as inhibition, at one concentration (the size of the read-out at that concentration, not a potency): < 5%
Compound 3 was reported as a limit (the forecaster's own chance of this, stated with the estimate: 50%); the middle value sits exactly at the limit.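

In this assay, hydrogen in place of benzylamino on an aromatic carbon next to the ring nitrogen gives a number at least 3 percentage points lower from compound 1 to compound 3 (that floor lies within the scatter). The result for compound 3, < 5%, is a limit of the assay and not a number. This is the first measured pair at this position, and it shows no difference beyond the scatter between benzylamino and hydrogen, with little room left in the read-out: the limit of < 5% in this assay, at which 2 of the 3 values shown sit.

Whether any group on this carbon can raise inhibition beyond the scatter stays open, since the compounds shown include neither a longer chain such as phenethylamino nor a carboxylic acid there. Going by these compounds alone, compound 2 differs from compound 1 in more than one place, so it gives no step for this position.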